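Solubility of a hydroxyisopropyl analogue replacing a ring fluorine

The source may report more compounds than this note shows. Statements on the series, on what has been measured and on what is new or still open speak of the compounds shown alone.

Compound 1 `CC(=O)NCc1cccc(Cn2nc(NS(=O)(=O)c3ccc(Cl)s3)c3ccccc32)c1`: >= 117 ug/mL, a limit
Compound 2 `CC(=O)NCc1cccc(Cn2nc(NS(=O)(=O)c3ccc(Cl)s3)c3c(F)cccc32)c1`: >= 139 ug/mL, a limit

In a physicochemical assay for solubility, read by chemiluminescence, measured as kinetic solubility (on this read-out higher numbers stand for higher solubility and lower numbers for lower solubility), compound 1 reaches only the limit >= 117 ug/mL. In this assay compound 2 likewise sits at the limit >= 139 ug/mL, so its standing on the numbers shown is known only as a limit (the limit of >= 139 ug/mL in this assay, at which 1 of the 2 values shown sits). Among the measured compounds shown here, the one measured step, a step that the two limits leave unreadable from compound 1 to compound 2, is therefore of unreadable size. Compound 3 `CC(=O)NCc1cccc(Cn2nc(NS(=O)(=O)c3ccc(Cl)s3)c3c(C(C)(C)O)cccc32)c1` carries 1-hydroxy-1-methylethyl in place of fluoro on an aromatic carbon. No readable step bears on this change, so no direction beyond the scatter can be expected for a step that the limit leaves unreadable from compound 2 to compound 3. Compound 3 is estimated at 150 ug/mL, between 60 ug/mL and 350 ug/mL.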

Compound 3, solubility: >= 159 ug/mL
Compound 3 was reported as a limit; the forecaster's own chance of this, stated with the estimate: 65%; middle value at least 1.0-fold (0.02 log units) away from the limit.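

In this assay compound 3 reaches only a limit, >= 159 ug/mL. None of the steps among compound 1, compound 2 and compound 3 can be read. On these data alone, whether hydrogen, fluoro or 1-hydroxy-1-methylethyl at this place makes any difference in solubility stays open.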